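The source may hold more compounds than are shown below. What is called first, only, known or untested is meant among the compounds shown, and "the series" means these compounds.

Going by the values given here, compound 1 `CCC(C)(C)Cc1c[nH]c(CCc2ccc(-c3cccc(C)n3)cc2)n1` gives 106 nM in a functional assay on HEK293 cells for agonist activity at Bombesin receptor subtype-3 (Mus musculus), read by luminescence and calcium flux, with a stated time of 10 min (on this read-out higher numbers stand for an effect only at larger amounts of compound and lower numbers for an effect already at smaller amounts), the highest of the two numbers known here; compound 2 `CCC(C)(C)Cc1c[nH]c(CCc2ccc(-c3cccnc3)cc2)n1` gives 97 nM. Among the compounds with values here, the only measured step, a 1.1-fold lower number from compound 1 to compound 2 (0.04 log units; within the scatter), lies within the scatter. Compound 3 `CCC(C)(C)Cc1c[nH]c(CCc2ccc(-c3ccns3)cc2)n1` differs from compound 1 by 1,2-thiazol-5-yl in place of 6-methylpyridin-2-yl on an aromatic carbon. Within the data shown here, the one step bearing on this change, a 1.1-fold lower number from compound 1 to compound 2 (0.04 log units; within the scatter), involved a swap of the same aromatic ring on an aromatic carbon and produced nothing beyond the scatter, so in this assay no shift beyond the scatter is expected, a 1.1-fold higher number from compound 1 to compound 3 (0.05 log units; within the scatter). Compound 3 is accordingly estimated at 120 nM, with an expected range from 40 nM to 400 nM.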

Compound 3, half-maximal effective concentration: 103 nM
The estimate for compound 3 lay 1.2-fold (0.07 log units) above the measured number; low and high end bracket the measured number.
By their numbers in this assay, from the lowest: compounds 2, 3 and 1 (each within the scatter of the next).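

In this assay, 1,2-thiazol-5-yl, a five-membered aromatic ring with 2 hetero atoms, gives no shift beyond the scatter at the aromatic carbon para to a large group, with a 1.0-fold lower number from compound 1 to compound 3 (0.01 log units; within the scatter) and a 1.1-fold higher number from compound 2 to compound 3 (0.03 log units; within the scatter) as the two steps. The earlier pair held only six-membered aromatic rings, so among these three compounds, ring size and the entry of sulfur also leave the number within the scatter. Nothing available explains this result. On these data alone, whether an amine, a carboxylic acid or a longer chain at this position would also stay within the scatter remains open.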